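This account rests on a few compounds, and the source may have more. Where it says the series, first, only, none or still open, it means among the compounds named here.

Three compounds in this set share one core, decorated with a benzyl‑ or trimethoxybenzyl‑triazole arm and varied at the fused six‑membered ring. For the measured compounds named here, compound 1 `COc1cc(Cn2cc(COc3cccc(/C=C4/C(=O)Nc5ccccc54)c3)nn2)cc(OC)c1` is the only one with a plain number in a functional assay on HeLa cells (Homo sapiens) for inhibition, read by MTT assay, with a stated time of 48 h; on this read-out lower numbers stand for stronger inhibition and higher numbers for weaker inhibition: compound 1 gives 22000 nM. Compound 2 `O=C1Nc2ccc(Cl)cc2/C1=C/c1cccc(OCc2cn(Cc3ccccc3)nn2)c1` has no single number in this assay; the entry for compound 2 stands as "not determined" (no result reported). For compound 3 `O=C1Nc2ccc([N+](=O)[O-])cc2/C1=C\c1cccc(OCc2cn(Cc3ccccc3)nn2)c1` the read‑out in this assay is a limit of the assay rather than a number, > 50000 nM. Thus one of the three values sits at the limit of > 50000 nM in this assay, at which 1 of the 3 values shown sits, and the series as a whole sits at the weak end of what this assay can report.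

Compound 4 `CC(=O)c1ccc2c(c1)/C(=C/c1cccc(OCc3cn(Cc4ccccc4)nn3)c1)C(=O)N2` differs from compound 2 by acetyl in place of chloro on an aromatic carbon. Going by the values given here, no measured pair in this set isolates that change, so no direction can be drawn from the data; the expectation is a step no larger than the scatter, with compound 4 staying in the same weak region as compound 1 and compound 3. Compound 4 is estimated at 30000 nM in this assay, with a range from 8000 nM to 60000 nM.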

Compound 4, half-maximal inhibitory concentration: > 50000 nM
Compound 4: a limit, no number; the forecaster's own chance of this, stated with the estimate: 40%; middle value at least 1.6-fold (0.22 log units) from the limit.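

In this assay compound 4 gives > 50000 nM, a limit of the assay and not a number. With compound 2 carrying no number there, no step can be read between compound 2 and compound 4. The compounds shown leave open how acetyl and chloro compare on the shared core in this assay.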